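Changing the Amide Chain on a Shared Core

A few compounds are considered here, and "the series" means these few. Any claim that something is new, unique, unknown or untested is made for them only; others in the source may bear on it.

In a functional assay on A549 cells (Homo sapiens) for inhibition, read by MTT assay, with a stated time of 48 h (on this read-out higher numbers stand for weaker inhibition and lower numbers for stronger inhibition), compound 1 (`CCCCN(CCCC)C(=O)/C=C/c1c(/C=C/c2ccc(OC)cc2)cc(OC)cc1OC`) gives 6160 nM and compound 2 (`CCCCCCNC(=O)/C=C/c1c(/C=C/c2ccc(OC)cc2)cc(OC)cc1OC`) gives 6230 nM. For the measured compounds named here, compound 2 therefore stands level with compound 1, the only other compound measured, and the two values lie within the scatter of each other.

Compound 3 (`COc1ccc(/C=C/c2cc(OC)cc(OC)c2/C=C/C(=O)N(CC(C)C)CC(C)C)cc1`) keeps the shared core but carries diisobutylamino in place of hexylamino on a carbonyl carbon. Going by the values given here, one measured step bears on this change. That step, a 1.0-fold higher number from compound 1 to compound 2 (0.00 log units; within the scatter), exchanged dibutylamino for hexylamino at the same kind of carbonyl carbon, and its size stays within the scatter. Among the compounds with values here, the new group resembles the dibutylamino of compound 1, but no branched chain has yet been measured, so this evidence is thin. A step beyond the scatter is therefore not expected in this assay, and no direction can be favoured. The estimated step is a 1.0-fold higher number from compound 2 to compound 3 (0.02 log units; within the scatter), which is expected to remain within the scatter. Compound 3 is expected to give 6500 nM, with an estimated range from 3000 nM to 14000 nM.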

Compound 3, half-maximal inhibitory concentration: 3350 nM
Estimate against measurement, compound 3: 1.9-fold (0.29 log units) above; the measured number falls inside the stated range.
By their numbers in this assay, from the lowest: compounds 3, 1 and 2 (each within the scatter of the next).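

Compound 3 gives this carbonyl carbon a branched chain, and in this assay neither of its steps separates it from the unbranched compounds: there is a 1.9-fold lower number from compound 2 to compound 3 (0.27 log units; within the scatter) and a 1.8-fold lower number from compound 1 to compound 3 (0.26 log units; within the scatter). Among these three compounds, then, hexylamino, dibutylamino and diisobutylamino cannot be told apart at this position, even though the exchange of hexylamino for diisobutylamino takes the count of hydrogen-bond donors on the group from 1 to 0 and the heavy atoms from 7 to 9. Nothing given here accounts for the numbers or shows what, if anything, this position contributes to them.

Three groups of similar size leave open whether any group at this carbonyl carbon can move the number beyond the scatter, as a small dimethylamino group, a longer dioctylamino chain or a hexyl chain ending in a carboxylic acid or an amine might. Going by these compounds, it also remains open whether the level seen here would hold on another read-out or another cell line, since all three numbers come from a single assay.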